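Hydroxy to Nitro: a Cytotoxicity Expectation

The source may hold more compounds than are shown below. What is called first, only, known or untested is meant among the compounds shown, and "the series" means these compounds.

Measured compounds:
compound 1, `CN(C)c1ccc(C2CC(c3cc4ccccc4o3)=NN2C(=O)c2ccncc2)cc1`: compound 1 gives > 210000 nM in an ADME assay on Vero cells (Chlorocebus sabaeus) for cytotoxicity, read by MTT assay, with a stated time of 72 h; a higher number here means a weaker inhibitor, a lower number a stronger inhibitor
compound 2, `CCn1cc(C(=O)N2N=C(c3cc4ccccc4o3)CC2c2ccccc2O)c(=O)c2ccc(C)nc21`: compound 2 gives > 157000 nM in this assay

Both values shown are limits of the assay rather than numbers. Compound 2 stands at such a limit, (the limit of > 157000 nM in this assay, at which 1 of the 2 values shown sits), and no number places it more exactly. Compound 1 likewise sits at a limit, (the limit of > 210000 nM in this assay, at which 1 of the 2 values shown sits). For the measured compounds named here, no step between measured compounds is known, so nothing in this assay has yet been tied to a change in structure.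

Compound 3, `CCn1cc(C(=O)N2N=C(c3cc4ccccc4o3)CC2c2ccccc2[N+](=O)[O-])c(=O)c2ccc(C)nc21`, differs from compound 2 in one place: nitro in place of hydroxy on an aromatic carbon. With only limits to rest on, the step from compound 2 to compound 3 in this assay is expected to be none beyond the scatter, a step that the limit leaves unreadable from compound 2 to compound 3, and compound 3 is expected most likely to be reported as a limit as well. For compound 3 the estimate in this assay is 200000 nM, with a range from 80000 nM to 500000 nM.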

Compound 3, half-maximal inhibitory concentration: > 85400 nM
Compound 3 ended at the assay's limit (the forecaster's own chance of this, stated with the estimate: 80%); the middle value does not contradict the limit.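

In this assay compound 3 gives > 85400 nM, a limit of the assay. Compound 2 also gives a limit, > 157000 nM, and the step from compound 2 to compound 3 cannot be read. Whether nitro in place of hydroxy changes the read-out at all stays open: all the compounds shown carry limits, not numbers.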